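From nitrile to chlorine on the imidazole benzyl arm

This account rests on a few compounds, and the source may have more. Where it says the series, first, only, none or still open, it means among the compounds named here.

Compound 1 has the structure `COC(=O)[C@H](CCSC)NC(=O)c1ccc(NCc2cncn2Cc2ccc(C#N)cc2)cc1-c1ccccc1`. In a functional assay on NIH3T3 cells (Mus musculus) (a lower number here means that less compound is needed, a higher number that more compound is needed for the effect), compound 1 gives > 10 uM, which is a limit of the assay rather than a number. Compound 2, `N#Cc1ccc(Cn2cncc2CNc2ccc(C(=O)NCC3CCCCC3)c(-c3ccccc3)c2)cc1`, carries cyclohexylmethyl in place of 1-(methoxycarbonyl)-3-(methylsulfanyl)propyl on an amide-type nitrogen. In this assay compound 2 gives > 10 uM, again a limit. Compound 3, `N#Cc1ccc(Cn2cncc2CNc2ccc(C(=O)Nc3cccc([N+](=O)[O-])c3)c(-c3ccccc3)c2)cc1`, carries 3-nitrophenyl on an amide-type nitrogen. In this assay compound 3 gives > 10 uM, also a limit. The three steps among them, a step that the two limits leave unreadable from compound 1 to compound 2, a step that the two limits leave unreadable from compound 1 to compound 3 and a step that the two limits leave unreadable from compound 2 to compound 3, therefore cannot be sized, since every value sits at the limit of > 10 uM in this assay, at which 3 of the 3 values shown sit.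

Compound 4, `COC(=O)[C@H](CCSC)NC(=O)c1ccc(NCc2cncn2Cc2ccccc2Cl)cc1-c1ccccc1`, differs from compound 1 in another part of the molecule: 2-chlorophenyl in place of 4-cyanophenyl on a saturated chain carbon bound to an aromatic nitrogen. Among the measured compounds shown here, none of the measured steps touches this position, and all of them are unreadable in any case, so they offer neither a size nor a direction for the change in this assay. With nothing pointing to a gain, compound 4 is expected to give about 15 uM, with a range from 3 uM to 60 uM, and most likely to be reported again only as a limit. That estimate corresponds to a step that the limit leaves unreadable from compound 1 to compound 4, which is expected to remain within the usual scatter.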

Compound 4, concentration for half-maximal effect: > 10 uM
Compound 4 was reported as a limit; the forecaster's own chance of this, stated with the estimate: 75%; the middle value is on the limit's open side.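

In this assay compound 4 gives > 10 uM as a limit of the assay, not a number. Compound 1 is also known only as a limit, so the step from 4-cyanobenzyl to 2-chlorobenzyl cannot be sized, and neither can any other step here: the limit of > 10 uM in this assay, at which 4 of the 4 values shown sit. The compounds shown leave open whether either change affects the result, and in which direction.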